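This account rests on a few compounds, and the source may have more. Where it says the series, first, only, none or still open, it means among the compounds named here.

Measured so far:
compound 1 `Nc1scc(CN2CCN(c3cccc(C(F)(F)F)c3)CC2)c1C(=O)c1ccc(Cl)cc1`: 0%
compound 2 `Nc1scc(CN2CCN(C3CCCCCC3)CC2)c1C(=O)c1ccc(Cl)cc1`: 0%

In an assay on CHO cells for displacement of a labelled ligand from adenosine receptor A3 (Homo sapiens), read by scintillation counting, with a stated time of 120 min, tested at 10 uM (on this read-out higher numbers stand for more inhibition at the one concentration tested (going by the name of the read-out) and lower numbers for less inhibition), compound 2 stands level with compound 1 at the digits shown, and the one recorded step, no change at the digits printed from compound 1 to compound 2 (within the scatter), is no change within the scatter. Compound 3 `Nc1scc(CN2CCN(c3cccc(F)c3)CC2)c1C(=O)c1ccc(Cl)cc1` differs from compound 2 by 3-fluorophenyl in place of cycloheptyl on an amine nitrogen in a ring. Since swapping the aromatic ring of compound 1 for the seven-membered ring of compound 2 left this assay unmoved, and compound 3 brings back an aromatic ring, no step beyond the scatter is expected. The step from compound 2 to compound 3 is expected to be a number 1 percentage points higher from compound 2 to compound 3 (within the scatter). Compound 3 is therefore estimated at 1%, between -10% and 15%.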

Compound 3, a percentage reported as inhibition, at one concentration (the size of the read-out at that concentration, not a potency): 4%
Compound 3: the middle estimate sits 3 percentage points below what was measured; low and high end bracket the measured number.
By their numbers in this assay, from the lowest: compounds 1, 2 and 3 (each within the scatter of the next).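

In this assay, the 3-fluorophenyl group on the amine nitrogen in a ring reads much like cycloheptyl, with a number 4 percentage points higher from compound 2 to compound 3 (within the scatter). On the aromatic ring, fluoro in place of trifluoromethyl also leaves the read-out unmoved beyond the usual noise, with a number 4 percentage points higher from compound 1 to compound 3 (within the scatter), so neither the ring type nor this ring substituent has yet shifted the result. Nothing available here explains why these groups read alike. Still open, going by these compounds, is whether a different group on this nitrogen, such as a carboxylic acid or a longer chain, would give real inhibition, and whether changes elsewhere on the shared core would.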